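The source may hold more compounds than are shown below. What is called first, only, known or untested is meant among the compounds shown, and "the series" means these compounds.

Working notes on the series. Three compounds share one core and have been run in a functional assay on BGC-823 cells (Homo sapiens) for inhibition, read by MTT assay, with a stated time of 72 h; a lower number here means a stronger inhibitor, a higher number a weaker inhibitor. Compound 1, `C[C@@H]1CCN(c2cc(-c3ccccc3)nc3ncnn23)C[C@@H]1N(C)c1ncnc2[nH]ccc12`, gives only a limit of the assay in this assay, > 100000 nM, as recorded in the limit of > 100000 nM in this assay, at which 1 of the 3 values shown sits. Compound 2, `CCc1cc(N2CC[C@@H](C)[C@@H](N(C)c3ncnc4[nH]ccc34)C2)n2ncnc2n1`, gives 82200 nM in this assay. Among the measured compounds shown here, the single measured step, an at least 1.2-fold lower number from compound 1 to compound 2 (0.08 log units; that floor lies within the scatter), rests on a limit and says little about the size of any change. Compound 3, `Cc1cc(N2CC[C@@H](C)[C@@H](N(C)c3ncnc4[nH]ccc34)C2)n2nc(SCc3ccccc3Br)nc2n1`, gives 81100 nM in this assay; among the two numbers reported it is the lower one, but its gap to compound 2 lies within the scatter. The third value, that of compound 1, is a limit of the assay. Compound 4, `Cc1cc(N2CC[C@@H](C)[C@@H](N(C)c3ncnc4[nH]ccc34)C2)n2nc(SCc3ccccc3)nc2n1`, remains to be measured. It differs from compound 3 by hydrogen in place of bromo on an aromatic carbon. For the measured compounds named here, no measured step touches the (2-bromobenzyl)sulfanyl group, so the step from compound 1 to compound 2 does not bear on this change. Compound 4 is therefore expected to sit near compound 3, with a step of a 1.0-fold higher number from compound 3 to compound 4 (0.02 log units; within the scatter) that stays within the scatter. The estimate for compound 4 in this assay is 85000 nM, expected between 40000 nM and 180000 nM.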

Compound 4, half-maximal inhibitory concentration: 14400 nM
Estimate against measurement, compound 4: 5.9-fold (0.77 log units) above, outside the stated range (below it).
By their numbers in this assay, from the lowest: compound 4; then compounds 3 and 2 (each within the scatter of the next). At a limit, above all of these: compound 1.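

In this assay, among the compounds shown here, hydrogen in place of bromo on the aromatic carbon ortho to a large group gives a 5.6-fold lower number from compound 3 to compound 4 (0.75 log units; beyond the scatter), the first step read between two numbers and beyond the scatter. For the compounds shown here, the 2-bromobenzyl to benzyl change therefore alters the read-out, and this position, which no earlier step touched, is not silent in the assay. The data in hand give no measured property that accounts for the size or direction of this step.

From the compounds shown here alone, whether a fluoro, chloro, methyl or methoxy group on this carbon would read closer to hydrogen or to bromo remains open, as does the effect of any of these groups elsewhere on the six-membered ring. Also open is how far the benzylsulfanyl group itself contributes, since no pair shown isolates it.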